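The source may report more compounds than this note shows. Statements on the series, on what has been measured and on what is new or still open speak of the compounds shown alone.

Measured compounds:
compound 1, `COc1ccc2c(-c3cc(C(F)(F)F)c(C#N)c(-c4cn(S(=O)(=O)c5ccc(C)cc5)c5cc(OC)ccc45)n3)cn(S(=O)(=O)c3ccc(C)cc3)c2c1` — in a functional assay on A549 cells (Homo sapiens) for inhibition, tested at 10 uM (a lower number here means a weaker effect, a higher number a stronger effect of the compound at the concentration tested), compound 1 gives 13.3%
compound 2, `COc1ccc2c(c1)c(-c1cc(C(F)(F)F)ccn1)cn2S(=O)(=O)c1ccc(C)cc1` — in this assay compound 2 gives 9.9%

The two numbers lie close together, and the gap between compound 2 and compound 1 is within the usual scatter of repeated runs. Compound 2 therefore stands alongside compound 1, with nothing separating the two beyond the scatter; both readings are weak at the single concentration tested.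

Compound 3, `Cc1ccc(S(=O)(=O)n2cc(-c3cc(C(F)(F)F)ccn3)c3ccccc32)cc1`, differs from compound 2 in one place: hydrogen in place of methoxy on an aromatic carbon. The methoxy leaves from an aromatic carbon of the six-membered aromatic ring of carbon only, meta and para to a fused ring, and a hydrogen enters there. Within the data shown here, no step between two measured compounds is available, so the effect of this change has no precedent.

The expected step is a number 0.9 percentage points lower from compound 2 to compound 3 (within the scatter), that is none beyond the scatter. Compound 3 is expected to give 9%, with a range from 0% to 20%.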

Compound 3, a percentage reported as inhibition, at one concentration (the size of the read-out at that concentration, not a potency): 35%
For compound 3 the middle estimate is 26 percentage points below the measured one, and the stated range ends below it.
By their numbers in this assay, from the lowest: compounds 2 and 1 (each within the scatter of the next); then compound 3.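

Hydrogen in place of methoxy on this aromatic carbon, meta to a fused ring and para to a fused ring, gives in this assay a number 25.1 percentage points higher from compound 2 to compound 3 (beyond the scatter). Among these compounds, this is the first single-place change to move the read-out beyond the scatter, so what sits on this carbon matters for the size of the effect at the concentration tested, and the methoxy is not required for that effect in this pair. Nothing available bears on the reason for this step.

On these data alone, whether an amine, a carboxylic acid, a fluorine or a longer alkoxy chain on this carbon would read like compound 2 or like compound 3 remains open. Also open, as far as these compounds go, is whether the same exchange would give a similar step in the core of compound 1, and a read-out at a single concentration tells only the size of the effect at that concentration.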